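Swapping Cyclohexyloxy for Tert-Butyl in a Level Series

This account rests on a few compounds, and the source may have more. Where it says the series, first, only, none or still open, it means among the compounds named here.

In a functional assay on HT-29 cells (Homo sapiens) for inhibition, read by sulforhodamine B assay, with a stated time of 48 h (on this read-out lower numbers stand for stronger inhibition of growth and higher numbers for weaker inhibition of growth), compound 2 (`O=C(CCl)NC(=O)Nc1ccc(OC2CCCCC2)cc1`) gives 3100 nM and stands level with compound 1 (`O=C(CCl)NC(=O)Nc1ccc(OC2CCCC2)cc1`), which gives 3100 nM as well, while compound 3 (`O=C(CCl)NC(=O)Nc1ccc(OCc2ccccc2)cc1`) gives 2600 nM within the scatter of both. Compound 4 (`CC(C)(C)c1ccc(NC(=O)NC(=O)CCl)cc1`) carries tert-butyl in place of cyclohexyloxy on an aromatic carbon. Among the compounds with values here, the steps that bear on this are no change at the digits printed from compound 1 to compound 2 (within the scatter) and a 1.2-fold lower number from compound 2 to compound 3 (0.08 log units; within the scatter) and both only alter the group on the oxygen. Within the data shown here, no measured compound lacks that oxygen, so the change is untested directly, and no step beyond the scatter is expected in this assay for it. The estimated step is no change at the digits printed from compound 2 to compound 4 (within the scatter) and stays inside the scatter. Compound 4 is expected to give 3100 nM within an estimated range from 1200 nM to 8000 nM in this measurement.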

Compound 4, concentration for 50% growth inhibition: 3300 nM
Estimate against measurement, compound 4: 1.1-fold (0.03 log units) below, within the range that was stated.
By their numbers in this assay, from the lowest: compounds 3, 1, 2 and 4 (each within the scatter of the next).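

In this assay, the oxygen on the aromatic carbon gives way to tert-butyl with a 1.1-fold higher number from compound 2 to compound 4 (0.03 log units; within the scatter) and with a 1.1-fold higher number from compound 1 to compound 4 (0.03 log units; within the scatter). Within the data shown here, neither the oxygen nor the ring of carbon only is therefore needed at this place for the number to stay within the scatter, a point that the earlier compounds, which all keep the oxygen, could not show. Nothing at hand explains why the values stay level. Still open, on these data alone, is whether an amine or a carboxylic acid at this place would stay level as well.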